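This account rests on a few compounds, and the source may have more. Where it says the series, first, only, none or still open, it means among the compounds named here.

Measured so far in a functional assay on RBL-2H3 cells (Rattus norvegicus) for inhibition; on this read-out higher numbers stand for weaker inhibition and lower numbers for stronger inhibition:
compound 1 `Cc1cc(C)nc(N/C(S)=N/[C@@H](C)c2cccc3ccccc23)c1` gives > 100000 nM, a limit of the assay.
compound 2 `COc1ccc2nc(/N=C(\S)N[C@H](C)c3cccc4ccccc34)sc2c1` gives > 100000 nM, likewise a limit.
compound 3 `Cc1cc(C)nc(N/C(S)=N/[C@H](C)c2cccc3ccccc23)c1` gives > 100000 nM, likewise a limit.

Compound 1 stands at the limit of this assay, as does every other measured compound, so no number is known for any of them. Among the measured compounds shown here, the one single-point step, a step that the two limits leave unreadable from compound 1 to compound 3, cannot be read because of the limit of > 100000 nM in this assay, at which 3 of the 3 values shown sit, even though (the fact that compounds 1 and 3 differ only in the configuration as drawn). Compound 4 `C[C@H](/N=C(\S)Nc1ccccn1)c1cccc2ccccc12` differs from compound 1 by pyridin-2-yl in place of 4,6-dimethylpyridin-2-yl on an amine nitrogen. For the measured compounds named here, no measured step bears on this change, and the shared limit gives no direction. The expectation is therefore that compound 4 also sits at or near the limit, with the step that the limit leaves unreadable from compound 1 to compound 4 expected to be no larger than scatter. Compound 4 is estimated at 150000 nM, within 30000 nM to 1000000 nM.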

Compound 4, half-maximal inhibitory concentration: > 100000 nM
Compound 4 ended at the assay's limit; the forecaster's own chance of this, stated with the estimate: 80%; the middle value does not contradict the limit.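

Among the compounds shown here, compound 1 and compound 4 both sit at the limit of this assay, so no step between them can be read. The compounds shown leave open what pyridin-2-yl in place of 4,6-dimethylpyridin-2-yl does to inhibition, and whether any member of this series gives a readable value.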